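Lengthening an isothiocyanate chain on two related cores

A few compounds are considered here, and "the series" means these few. Any claim that something is new, unique, unknown or untested is made for them only; others in the source may bear on it.

Three compounds were measured in a functional assay on A549 cells (Homo sapiens) for inhibition, read by CCK-8 assay, with a stated time of 72 h, tested at 1 uM; on this read-out lower numbers stand for a weaker effect and higher numbers for a stronger effect at the one concentration tested. Compound 1 `CN(C)C(=O)c1cc2cnc(Nc3ccc(S(=O)(=O)NCCCCCCN=C=S)cc3)nc2n1C1CCCC1` gives 49.5%, and compound 2 `CN(C)C(=O)c1cc2cnc(Nc3ccc(S(=O)(=O)NCCCCCCCN=C=S)cc3)nc2n1C1CCCC1` gives 32.6%. The change between them, (a group of 4 heavy atoms (2 carbon, 1 nitrogen, 1 sulfur; no ring) in place of a group of 3 heavy atoms (1 carbon, 1 nitrogen, 1 sulfur; no ring), on a saturated chain carbon, six bonds along the chain from a sulfonamide nitrogen), produced the step of a number 16.9 percentage points lower from compound 1 to compound 2 (beyond the scatter). Compound 3 `CN(C)C(=O)c1cc2cnc(Nc3ccc(C(=O)NCCCCN=C=S)cc3)nc2n1C1CCCC1` gives 30.2%; how its core differs from that of compound 1 is not broken down here. Compound 4 `CN(C)C(=O)c1cc2cnc(Nc3ccc(C(=O)NCCCCCN=C=S)cc3)nc2n1C1CCCC1` is not yet measured. It differs from compound 3 by a group of 4 heavy atoms (2 carbon, 1 nitrogen, 1 sulfur; no ring) in place of a group of 3 heavy atoms (1 carbon, 1 nitrogen, 1 sulfur; no ring), on a saturated chain carbon, four bonds along the chain from an amide-type nitrogen, the same kind of change as from compound 1 to compound 2, though here on a saturated chain carbon four bonds along the chain from an amide-type nitrogen rather than six bonds from a sulfonamide nitrogen. Going by the values given here, a step of similar size is expected, a number 12.2 percentage points lower from compound 3 to compound 4 (beyond the scatter), because the only measured instance gave a number 16.9 percentage points lower from compound 1 to compound 2 (beyond the scatter). Compound 4 is therefore estimated at 18%, between 5% and 35%.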

Compound 4, a percentage reported as inhibition, at one concentration (the size of the read-out at that concentration, not a potency): 29.3%
The estimate for compound 4 lay 11.3 percentage points below the measured number, and the stated range covers the measured number.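

On the core of compound 3, the same lengthening of the isothiocyanate chain gave a number 0.9 percentage points lower from compound 3 to compound 4 (within the scatter) in this assay, so the step seen on the other core did not carry over. Going by these compounds alone, the two steps do not agree: the same change on two cores in this assay, a number 16.9 percentage points lower (beyond the scatter) from compound 1 to compound 2 and a number 0.9 percentage points lower (within the scatter) from compound 3 to compound 4, 16 percentage points apart, beyond the scatter of two such steps This does not show which difference between the pairs matters, since the change sits six bonds along the chain from a sulfonamide nitrogen in one and four bonds from an amide-type nitrogen in the other, and each core offers only one such step.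

Going by these compounds, whether a longer chain on either core would follow either step remains open. So does whether an amine or a carboxylic acid at the chain end would retain the inhibition.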